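This account rests on a few compounds, and the source may have more. Where it says the series, first, only, none or still open, it means among the compounds named here.

Three compounds have been measured in a functional assay on NCI-H460 cells (Homo sapiens) for antiproliferative activity, read by CCK-8 assay, with a stated time of 72 h, tested at 8 uM; on this read-out lower numbers stand for a weaker effect and higher numbers for a stronger effect at the one concentration tested:

compound 1 `COC(CCn1cnc2c(NCc3ccc(C(=O)Nc4ccccc4N)cc3)nc(Cl)nc21)OC` gives 51.2%
compound 2 `Nc1ccccc1NC(=O)/C=C/c1ccc(Cn2cnc3c(Nc4ccccc4)nc(Cl)nc32)cc1` gives 28.7%
compound 3 `Nc1ccccc1NC(=O)c1ccc(COCNc2nc(Nc3ccc(-c4ccccc4)cc3)c3ncn(C4CCCC4)c3n2)cc1` gives 41.6%

Compound 1 holds the highest of the three numbers. Compound 3 comes nearest, and the gap between compound 3 and compound 1 lies within the usual scatter of repeated measurements, so the two cannot be told apart on these numbers. Compound 2 lies furthest away, and its gap to compound 1 is beyond the scatter. Compounds 2 and 3 each differ from compound 1 in several places at once, so none of these gaps can be read as the effect of a single change.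

The next compound, compound 4 `CCCn1cnc2c(NCc3ccc(C(=O)Nc4ccccc4N)cc3)nc(Cl)nc21`, differs from compound 1 in one place only: methyl in place of dimethoxymethyl on a saturated chain carbon, two bonds along the chain from an aromatic nitrogen. Going by the values given here, no measured pair shows this change on its own, so there is nothing in the data to set its size by. With the rest of the molecule unchanged, the expected step in this assay is small and may not reach beyond the scatter in either direction. The estimated step is a number 6.2 percentage points lower from compound 1 to compound 4 (within the scatter). Compound 4 is accordingly expected to give 45%, within a range from 25% to 65%.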

Compound 4, a percentage reported as inhibition, at one concentration (the size of the read-out at that concentration, not a potency): 39.2%
Compound 4: middle estimate off by 5.8 percentage points, on the high side; the range from low to high includes it.
By their numbers in this assay, from the lowest: compound 2; then compounds 4, 3 and 1 (each within the scatter of the next, the first and the last beyond it).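

In this assay, going by these compounds alone, the change from dimethoxymethyl to methyl on a saturated chain carbon, two bonds along the chain from an aromatic nitrogen, is the first single change that can be read on its own, and it gives a number 12 percentage points lower from compound 1 to compound 4 (beyond the scatter). The end of this chain therefore has a modest but real bearing on the read-out: cutting 3,3-dimethoxypropyl back to propyl lowers the number, yet compound 4 still gives 39.2% at the one concentration tested, so the dimethoxymethyl group is not required for a measurable effect. No supporting measurement bears on why the number moves, so this pair gives the size of the step and not its reason.

As far as these compounds go, a single pair cannot separate the loss of the two oxygen atoms from the loss of the chain's length, and it remains open how a hydroxyl, an amine, a carboxylic acid or a longer chain would read at this place. From the compounds shown here alone, it also remains open whether the same change would produce a step of similar size on a different core.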